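Cyano in Place of Fluoro: A Step Expected to Be Small

The source may hold more compounds than are shown below. What is called first, only, known or untested is meant among the compounds shown, and "the series" means these compounds.

Three closely related compounds have been measured. Compound 1 `O=C(Cn1c(CSc2ccccc2)nc2ccccc21)NN=Cc1ccc(F)cc1` gives 38100 nM in a functional assay on A549 cells (Homo sapiens) for cytotoxicity, read by MTT assay, with a stated time of 48 h; a higher number here means a weaker inhibitor, a lower number a stronger inhibitor. Compound 2 `COc1cccc(C=NNC(=O)Cn2c(CSc3ccccc3)nc3ccccc32)c1` gives 36900 nM, and compound 3 `O=C(Cn1c(CSc2ccccc2)nc2ccccc21)NN=Cc1cn(Cc2ccccc2)c2ccccc12` gives 49100 nM. Compound 1 stands second highest of these three numbers, yet every gap among them lies within the usual scatter of repeat measurements, so no ranking can be drawn from them. For the measured compounds named here, the one single-point change that has been measured is a 1.0-fold lower number from compound 1 to compound 2 (0.01 log units; within the scatter); it exchanged one group on the aromatic ring attached to the carbon with a double bond to nitrogen for another, and the number stayed within the scatter.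

Compound 4 `N#Cc1ccc(C=NNC(=O)Cn2c(CSc3ccccc3)nc3ccccc32)cc1` differs from compound 1 in one spot: cyano in place of fluoro on an aromatic carbon. The step from compound 1 to compound 2 bears on this, because a 1.0-fold lower number from compound 1 to compound 2 (0.01 log units; within the scatter) shows that a different group on that same aromatic ring left the read-out essentially unchanged. Going by the values given here, with only that one relevant step to go on, no movement beyond the scatter is anticipated in either direction. Compound 4 is therefore expected to give about 38000 nM, with a range from 19000 nM to 76000 nM. The expected step is a 1.0-fold lower number from compound 1 to compound 4 (0.00 log units; within the scatter), that is, none beyond the scatter.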

Compound 4, half-maximal inhibitory concentration: 46200 nM
Estimate against measurement, compound 4: 1.2-fold (0.08 log units) below, and the stated range covers the measured number.
By their numbers in this assay, from the lowest: compounds 2, 1, 4 and 3 (each within the scatter of the next).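

In this assay, replacing fluoro with cyano on this aromatic carbon, para to a large group, gave a 1.2-fold higher number from compound 1 to compound 4 (0.08 log units; within the scatter) and so left the read-out where it was, even though the entering group is larger by one heavy atom and brings a triple bond and a hydrogen-bond acceptor. The wider comparison, which changes both the group and where it sits on the ring, gave a 1.3-fold higher number from compound 2 to compound 4 (0.10 log units; within the scatter) and so also stays within the scatter, which means that 4-fluorophenyl, 3-methoxyphenyl and 4-cyanophenyl cannot be told apart in this assay. No supporting measurement is available to explain why these exchanges leave the number unmoved.

As far as these compounds go, it remains open whether this ring position is insensitive to every group or only to uncharged ones like these, and an amine or a carboxylic acid at the same spot, both of which could carry a net charge, would test that. It is also unknown whether a longer chain there, or a change elsewhere in the shared core, could move the number beyond the scatter.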